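This account rests on a few compounds, and the source may have more. Where it says the series, first, only, none or still open, it means among the compounds named here.

Compound 1 `N#Cc1ccc(NCCNc2ncc(-c3ncc[nH]3)c(-c3ccc(Cl)cc3Cl)n2)nc1`: > 0.5 h
Compound 2 `Clc1ccc(-c2nc(NCCNc3ccccn3)ncc2-c2ncc[nH]2)c(Cl)c1`: > 0.5 h
Compound 3 `Nc1nc(NCCNc2ncc(-c3ncc[nH]3)c(-c3cc(F)c(F)cc3F)n2)ccc1[N+](=O)[O-]`: > 0.5 h

Each of these three readings in an ADME assay on microsomes from liver (Canis lupus familiaris) for metabolic stability (a higher number here means that the compound lasts longer, a lower number that the compound disappears faster), is a limit of the assay rather than a number. Compound 1 sits at that limit. Compound 2 sits at that limit as well. Compound 3 likewise gives only a limit in this assay. Accordingly, the step that the two limits leave unreadable from compound 1 to compound 2 cannot be read because both of its ends sit at the limit of > 0.5 h in this assay, at which 3 of the 3 values shown sit. Compound 3 therefore stands level with compounds 1 and 2 as far as the numbers go, and nothing separates any of the three.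

The unmeasured compound 4 `Nc1nc(NCCNc2ncc(-c3ncc[nH]3)c(-c3ccc(Cl)cc3Br)n2)ccc1[N+](=O)[O-]` differs from compound 3 in one place: 2-bromo-4-chlorophenyl in place of 2,4,5-trifluorophenyl on an aromatic carbon. For the measured compounds named here, no measured step touches either the trifluorophenyl or the bromochlorophenyl group, and the single measured step is unreadable, so there is no step to lean on for this change. With all three measured compounds at the limit, compound 4 is expected to reach the limit too, estimated at 0.7 h with a range from 0.4 h to 1.5 h. The implied step that the limit leaves unreadable from compound 3 to compound 4 is expected to stay within the scatter.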

Compound 4, half-life: > 0.5 h
Compound 4 gave a limit, no number; the forecaster's own chance of this, stated with the estimate: 75%; the middle value is on the limit's open side.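

In this assay compound 4 gives > 0.5 h, which is a limit and not a number. The step from compound 3 to compound 4 therefore cannot be read, as both ends rest on a limit: the limit of > 0.5 h in this assay, at which 4 of the 4 values shown sit.

The compounds shown leave open how long any of the four actually lasts, and whether swapping 2,4,5-trifluorophenyl for 2-bromo-4-chlorophenyl changes that.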